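Benzofuran pyrazolines: Vero cytotoxicity, ortho to para methoxyphenyl

The source may hold more compounds than are shown below. What is called first, only, known or untested is meant among the compounds shown, and "the series" means these compounds.

Measured so far:
- compound 1 `O=C(c1ccncc1)N1N=C(c2cc3ccccc3o2)CC1c1ccc(Cl)cc1` — > 220000 nM
- compound 2 `O=C(c1ccncc1)N1N=C(c2cc3ccccc3o2)CC1c1ccccc1Cl` — > 210000 nM
- compound 3 `CCn1cc(C(=O)N2N=C(c3cc4ccccc4o3)CC2c2ccccc2OC)c(=O)c2ccc(C)nc21` — > 187000 nM

All three results in an ADME assay on Vero cells (Chlorocebus sabaeus) for cytotoxicity, read by MTT assay, with a stated time of 72 h (on this read-out lower numbers stand for stronger inhibition and higher numbers for weaker inhibition), are limits of the assay, not numbers. Compound 1 gives > 220000 nM in this assay, a limit. Compound 2 gives > 210000 nM, also a limit. Compound 3 gives > 187000 nM, again a limit. Among the compounds with values here, the one measured step, a step that the two limits leave unreadable from compound 1 to compound 2, cannot be sized because the limit of > 220000 nM in this assay, at which 1 of the 3 values shown sits, and the limit of > 210000 nM in this assay, at which 1 of the 3 values shown sits, both sit at the ceiling of the assay. Within the data shown here, no compound in the set shows a readable cytotoxicity value.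

The next compound, compound 4 `CCn1cc(C(=O)N2N=C(c3cc4ccccc4o3)CC2c2ccc(OC)cc2)c(=O)c2ccc(C)nc21`, differs from compound 3 by 4-methoxyphenyl in place of 2-methoxyphenyl on a saturated ring carbon. Among the measured compounds shown here, the only comparable change in the set, the chlorophenyl move from compound 1 to compound 2, gave no readable step, and both ends stayed at their limits. On that basis no step beyond the scatter is expected, and the result for compound 4 in this assay is expected to be another limit rather than a number. The estimated step that the limit leaves unreadable from compound 3 to compound 4 for compound 4 is therefore expected to be essentially none. Compound 4 is estimated at 300000 nM, with a range from 150000 nM to 1000000 nM.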

Compound 4, half-maximal inhibitory concentration: > 156000 nM
Compound 4 was reported as a limit; the forecaster's own chance of this, stated with the estimate: 85%; the middle value does not contradict the limit.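

In this assay compound 3 gives > 187000 nM, a limit. Compound 4 gives > 156000 nM, also a limit, and no step can be read between compound 3 and compound 4. The compounds shown leave open at what concentration, if any, cytotoxicity would appear in this series.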